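Ester to Amide on a Weakly Inhibiting Biphenyl Core

This account rests on a few compounds, and the source may have more. Where it says the series, first, only, none or still open, it means among the compounds named here.

Compound 1 `CCOC(=O)c1cccc(-c2ccc(OCC)cc2)c1` gives 50000 nM in an assay on COS-7 cells for inhibition of patatin-like phospholipase domain-containing protein 2 (Mus musculus) (on this read-out higher numbers stand for weaker inhibition and lower numbers for stronger inhibition), the second highest of three numbers. Compound 2 `CCOC(=O)c1cccc(-c2ccc(N(C)C)cc2)c1` gives 40000 nM, and the step of a 1.3-fold lower number from compound 1 to compound 2 (0.10 log units; within the scatter) lies within the scatter. Compound 3 `CCOC(=O)c1cccc(-c2ccc(OCC)c(N)c2)c1` gives 140000 nM, and the step of a 2.8-fold higher number from compound 1 to compound 3 (0.45 log units; beyond the scatter) is a modest weakening. Compound 4 `CCNC(=O)c1cccc(-c2ccc(OCC)cc2)c1` differs from compound 1 in another place: ethylamino in place of ethoxy on a carbonyl carbon. Among the compounds with values here, neither measured step touches the carbonyl carbon, so no step bears directly on this change; both known steps were small, and nothing suggests a large move. Compound 4 is therefore expected to stay close to compound 1, with an estimated step of no change at the digits printed from compound 1 to compound 4 (within the scatter). The estimate for compound 4 is 50000 nM, expected between 20000 nM and 125000 nM.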

Compound 4, half-maximal inhibitory concentration: 90000 nM
Compound 4: the middle estimate sits 1.8-fold (0.26 log units) below what was measured; measured number inside the range.
By their numbers in this assay, from the lowest: compounds 2, 1, 4 and 3 (each within the scatter of the next, the first and the last beyond it).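

Ethylamino in place of ethoxy on a carbonyl carbon gives a 1.8-fold higher number from compound 1 to compound 4 (0.26 log units; within the scatter), the first step shown at this place. Exchanging ethoxycarbonyl for ethylcarbamoyl, with its change in hydrogen-bond donors and acceptors, therefore moves the number no further than the scatter. Nothing given here explains this result.

As far as these compounds go, whether a carboxylic acid or a longer chain on the carbonyl carbon would move the number beyond the scatter remains open. So does whether the dimethylamino and amino changes would carry over to the ethylcarbamoyl series.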